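The source may hold more compounds than are shown below. What is called first, only, known or untested is meant among the compounds shown, and "the series" means these compounds.

Within the data shown here, compound 2 `Cn1cc(-c2nc3c(-c4ccc(CNC(=O)c5ccc(C(C)(C)C)cn5)c(F)c4)ccnc3[nH]2)cn1` gives 0.3 10^-6 cm/s in an ADME assay on Caco-2 cells (Homo sapiens) for permeability, in the apical to basolateral direction (on this read-out lower numbers stand for lower permeability and higher numbers for higher permeability), the lowest of the two numbers measured so far; its nearest neighbour is compound 1 `Cn1cc(-c2nc3c(-c4ccc(CNC(=O)c5nc(C6(C)CC6)no5)c(F)c4)ccnc3[nH]2)cn1`, which in this assay gives 2.8 10^-6 cm/s. Compound 3 `CC1CC2(C1)CN(C(=O)NCc1ccc(-c3ccnc4[nH]c(-c5cnn(C)c5)nc34)cc1F)C2` has not yet been measured in this assay. The change from compound 2 to compound 3 is a group of 8 heavy atoms (7 carbon, 1 nitrogen; one four-membered non-aromatic ring of carbon only, one four-membered non-aromatic ring with 1 hetero atom) in place of a group of 10 heavy atoms (9 carbon, 1 nitrogen; one six-membered aromatic ring with 1 hetero atom), on a carbonyl carbon. Among the measured compounds shown here, only one measured step bears on it: a 9.3-fold lower number from compound 1 to compound 2 (0.97 log units; beyond the scatter), an exchange of groups at the same carbonyl carbon, though of other groups than here. That step shows that exchanges at this carbonyl carbon can move this assay beyond the scatter, but it does not settle the direction for the present change, and no other comparison is available. Compound 3 is therefore expected to give about 1 10^-6 cm/s in this assay, with a range from 0.2 10^-6 cm/s to 5 10^-6 cm/s. This estimate means a 3.3-fold higher number from compound 2 to compound 3 (0.52 log units; beyond the scatter), a modest rise expected mainly because compound 2 sits at 0.3 10^-6 cm/s and most exchanges at this position would be expected to leave room upward, but it remains uncertain and may fall within the scatter.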

Compound 3, apparent permeability: 8 10^-6 cm/s
Compound 3: the middle estimate sits 8.0-fold (0.90 log units) below what was measured; the whole stated range lies below it.
By their numbers in this assay, from the lowest: compound 2; then compound 1; then compound 3.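

In this assay, exchanges at this carbonyl carbon prove able to raise the number as well as lower it: the new group gives a 27-fold higher number from compound 2 to compound 3 (1.43 log units; beyond the scatter), and also a 2.9-fold higher number from compound 1 to compound 3 (0.46 log units; beyond the scatter). Among these compounds, compound 3 therefore stands highest of the three, with both of its steps beyond the scatter, and it is the only one of them whose group at this carbonyl carbon holds no aromatic ring. The order of the three also follows the heavy-atom count of that group, from the largest group in compound 2 to the smallest in compound 3, so the two features run together and these compounds cannot separate them. Nothing available here accounts for the rise.

The compounds shown leave open whether the higher number needs the four-membered rings of the new group, or whether a single saturated ring such as piperidine or morpholine, bound to the same carbonyl carbon, would give a similar number. Among the compounds shown here, they also leave open whether the methyl group on the carbon-only ring of compound 3 matters, since no compound here lacks it or carries an ethyl group there.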